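Cytotoxicity in the series: bromo exchanged for trifluoromethyl

The compounds below may be only part of what the source reports. "The series", "measured", "known", "first", "only" and "open" are said of these compounds alone.

Three compounds of the shared core have been run in a functional assay on cells (Homo sapiens) for cytotoxicity; a higher number here means that more compound is tolerated, a lower number that less compound is tolerated. Compound 1 `O=C1N(CCCCCCOc2ccc(C(F)(F)F)cc2)CCN1c1ccncc1` reaches only the limit of the assay, giving > 25000 nM. Compound 2 `O=C1N(CCCCCCOc2ccc(C(F)(F)F)cc2)CCN1c1ccnc(Cl)c1` likewise stops at the limit, giving > 25000 nM. The step that the two limits leave unreadable from compound 1 to compound 2 therefore cannot be read. Compound 3 `O=C1N(CCCCCCOc2ccc(Br)cc2)CCN1c1ccccc1` also sits at the limit, with > 25000 nM in this assay . Where compound 3 stands is thus known only as a limit, and the same holds for the other two values, as the limit of > 25000 nM in this assay, at which 3 of the 3 values shown sit, shows.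

Compound 4 `O=C1N(CCCCCCOc2ccc(C(F)(F)F)cc2)CCN1c1ccccc1` differs from compound 3 by trifluoromethyl in place of bromo on an aromatic carbon, para to a large group. Within the data shown here, no measured step bears directly on this exchange, and the only step available, a step that the two limits leave unreadable from compound 1 to compound 2, concerns another position and is itself unreadable. Compound 1 already carries the trifluoromethyl group and stops at the limit. Compound 2 carries it as well and also stops at the limit. A step beyond the scatter is therefore not expected, and the expected step is a step that the limit leaves unreadable from compound 3 to compound 4. Compound 4 is estimated at 30000 nM, within 18000 nM to 60000 nM, and is expected most likely to be reported again only as a limit in this assay .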

Compound 4, half-maximal cytotoxic concentration: > 25000 nM
Compound 4 was reported as a limit (the forecaster's own chance of this, stated with the estimate: 85%); the middle value does not contradict the limit.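

In this assay compound 4 gives > 25000 nM, which is a limit. Among these compounds, no step among compound 1, compound 2, compound 3 and compound 4 can be read: the limit of > 25000 nM in this assay, at which 4 of the 4 values shown sit. The compounds shown leave open whether any exchange here alters cytotoxicity, and how far each compound lies from that limit.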